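The compounds below may be only part of what the source reports. "The series", "measured", "known", "first", "only" and "open" are said of these compounds alone.

Compound 2 `CNc1nc(N2CCN(C)CC2)cc2ccccc12` stands as the lowest number of the two measured here. In an assay on HEK293 cells for displacement of a labelled ligand from 5-hydroxytryptamine receptor 3A (Homo sapiens), read by scintillation counting, with a stated time of 24 h, in the presence of a further agent that is not named here (a lower number here means a stronger inhibitor, a higher number a weaker inhibitor), compound 2 gives 5.89 nM, while its nearest neighbour, compound 1 `CN1CCN(c2cc3ccccc3c(N)n2)CC1`, gives 219 nM in this assay. Compound 3 `CN1CCN(c2cc3ccccc3cn2)CC1` is the unmeasured member; it differs from compound 2 by hydrogen in place of methylamino on an aromatic carbon, so the whole methylamino group is gone and only the core of compound 2 with its bare ring carbon remains. Among the compounds with values here, the one measured step that bears on this position is a 37-fold lower number from compound 1 to compound 2 (1.57 log units; beyond the scatter), where a methyl on that nitrogen was added, and the step was large. Compound 3 goes the other way, removing the nitrogen itself, so a sizeable move toward higher numbers is expected, and the step expected from compound 2 to compound 3 is a 100-fold higher number from compound 2 to compound 3 (2.01 log units; beyond the scatter). Compound 3 is therefore estimated at 600 nM in this assay, with a range from 100 nM to 4000 nM.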

Compound 3, inhibition constant: 1.62 nM
For compound 3 the middle estimate is 370-fold (2.57 log units) above the measured one; measured number below the stated range.
By their numbers in this assay, from the lowest: compound 3; then compound 2; then compound 1.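

The earlier step showed only that methyl on the nitrogen improves on amino, and it left open whether that nitrogen is needed at all. With hydrogen on this aromatic carbon, next to the ring nitrogen, the result is a 3.6-fold lower number from compound 2 to compound 3 (0.56 log units; beyond the scatter), so a low number does not depend on a methylamino group at this position, and methylamino gives a higher number here than hydrogen does. The same replacement in the amino compound gives a 140-fold lower number from compound 1 to compound 3 (2.13 log units; beyond the scatter), so among the three compounds amino is the least favourable group at this position, and adding methyl to it recovers much, but not all, of the difference; nothing shown here explains these differences.

From the compounds shown here alone, it remains open whether a methoxy group, a chlorine atom or a longer chain such as ethylamino at this carbon would fall above or below compound 3. Going by these compounds, it is also open whether the order of hydrogen, methylamino and amino would hold on a changed core.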